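A new group on the chain of compound 3

The source may report more compounds than this note shows. Statements on the series, on what has been measured and on what is new or still open speak of the compounds shown alone.

Measured in a functional assay on HepG2 cells (Homo sapiens) for inhibition, read by MTT assay, with a stated time of 48 h; on this read-out higher numbers stand for weaker inhibition and lower numbers for stronger inhibition:
- compound 1 `CCSc1nnc(-c2cc(OC)c(OC)c(OC)c2)n1-c1ccc(OC)cc1`: > 60000 nM, a limit of the assay and not a number
- compound 2 `COc1ccc(-n2c(SCc3ccc(C)cc3)nnc2-c2cc(OC)c(OC)c(OC)c2)cc1`: 31600 nM
- compound 3 `COc1ccc(CSc2nnc(-c3cc(OC)c(OC)c(OC)c3)n2-c2ccc(OC)cc2)cc1`: 41100 nM

Compound 3 has one close neighbour on these numbers. The gap is a 1.3-fold higher number from compound 2 to compound 3 (0.11 log units; within the scatter), so the two cannot be told apart.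

The next compound to consider is compound 4 `COc1ccc(-n2c(SCC(=O)c3ccc(F)cc3)nnc2-c2cc(OC)c(OC)c(OC)c2)cc1`. It keeps the shared core and changes in one place: (4-fluorophenyl)carbonyl in place of 4-methoxyphenyl on a saturated chain carbon bound to a sulfur. In words, (4-fluorophenyl)carbonyl stands in place of 4-methoxyphenyl on a saturated chain carbon bound to a sulfur.

Changes at this same place have so far moved the number little: there is an at least 1.8-fold lower number from compound 1 to compound 2 (0.27 log units; that floor lies within the scatter), and there is an at least 1.4-fold lower number from compound 1 to compound 3 (0.16 log units; that floor lies within the scatter). Among the compounds with values here, no measured compound carries a carbonyl there, so the forecast stays loose. From these small steps, the expected change is a 1.5-fold lower number from compound 3 to compound 4 (0.17 log units; within the scatter), with nothing clearly beyond the scatter. The estimated value for compound 4 is 28000 nM, with an expected range from 9000 nM to 60000 nM.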

Compound 4, half-maximal inhibitory concentration: 10700 nM
Compound 4: middle estimate off by 2.6-fold (0.42 log units), on the high side; the measured number falls inside the stated range.
By their numbers in this assay, from the lowest: compound 4; then compounds 2 and 3 (each within the scatter of the next). At a limit, above all of these: compound 1.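

In this assay, within the data shown here, this is the first step at the saturated chain carbon bound to a sulfur that clearly clears the scatter: (4-fluorophenyl)carbonyl gives a 3.8-fold lower number from compound 3 to compound 4 (0.58 log units; beyond the scatter), and a 3.0-fold lower number from compound 2 to compound 4 (0.47 log units; beyond the scatter). The aryl swap between the two earlier compounds at this place, by contrast, gave only a 1.3-fold higher number from compound 2 to compound 3 (0.11 log units; within the scatter), so the position responds to some changes and not to others. Compound 1 carries a limit of the assay and not a number, so an at least 5.6-fold lower number from compound 1 to compound 4 (0.74 log units; beyond the scatter) is only a floor: the limit of > 60000 nM in this assay, at which 1 of the 4 values shown sits.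

The new group brings a carbonyl and a fluorine together, so the compounds shown cannot say which of the two goes with the step. A plain phenylcarbonyl, a 4-methoxyphenylcarbonyl or an amine on this chain would be needed to tell how far the effect depends on either part.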